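Isopropyl added ortho to the hydroxy: notes toward compound 3

The compounds below may be only part of what the source reports. "The series", "measured", "known", "first", "only" and "open" are said of these compounds alone.

Measured so far:
compound 1 `CCC(c1ccc(O)c(OC)c1)c1cccc(O)c1O`: 96%
compound 2 `CCC(c1ccc(O)c(OC)c1)c1ccccc1O`: 96%

In a functional assay for inhibition, with a stated time of 36 h, tested at 100 ug/mL (on this read-out lower numbers stand for less inhibition and higher numbers for more inhibition at the one concentration tested (going by the name of the read-out)), compound 1 gives 96% and compound 2 gives 96%. For the measured compounds named here, the single measured step, no change at the digits printed from compound 1 to compound 2 (within the scatter), is flat, so compound 2 stands level with compound 1 near the top of the percentage scale. Compound 3 (`CCC(c1ccc(O)c(OC)c1)c1cccc(C(C)C)c1O`) differs from compound 2 by isopropyl in place of hydrogen on an aromatic carbon. Going by the values given here, no measured step adds an isopropyl; the step from compound 1 to compound 2 bears on it only in showing the read-out insensitive to a change on this ring. Compound 3 is therefore expected to stay close, at 93%, between 80% and 99%. The expected step is a number 3 percentage points lower from compound 2 to compound 3 (within the scatter), none beyond the scatter.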

Compound 3, a percentage reported as inhibition, at one concentration (the size of the read-out at that concentration, not a potency): 96%
Compound 3: middle estimate off by 3 percentage points, on the low side; the measured number falls inside the stated range.
By their numbers in this assay, from the lowest: compounds 1, 2 and 3 (each within the scatter of the next).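

In this assay, for the compounds shown here, isopropyl in place of hydrogen on the aromatic carbon ortho to a hydroxy group shows no change at the digits printed from compound 2 to compound 3 (within the scatter), the first evidence that a carbon group is accepted at this position. Isopropyl in place of hydroxy at the same carbon shows no change at the digits printed from compound 1 to compound 3 (within the scatter), so hydrogen, hydroxy and isopropyl are not told apart here by this assay. No supporting measurement bears on why this position is so flat. As far as these compounds go, whether an amine or a carboxylic acid at this carbon would move the read-out remains open. So does whether the three compounds would separate at a concentration other than the one tested.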